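Removing one chloro from the dichlorophenyl amine

This account rests on a few compounds, and the source may have more. Where it says the series, first, only, none or still open, it means among the compounds named here.

Measured so far:
compound 1 `CC(C)c1ccc(Nc2ccc3c(OCCCN4CCN(C)CC4)cccc3n2)cc1`: 2170 nM in a functional assay on UACC-62 cells (Homo sapiens) for inhibition, read by sulforhodamine B assay, with a stated time of 48 h; on this read-out lower numbers stand for stronger inhibition of growth and higher numbers for weaker inhibition of growth
compound 2 `CN1CCN(CCCOc2cccc3nc(Nc4cc(Cl)cc(Cl)c4)ccc23)CC1`: 1950 nM in this assay

Compound 2 holds the lowest of the two numbers, but its gap to compound 1 is within the scatter, as the step of a 1.1-fold lower number from compound 1 to compound 2 (0.05 log units; within the scatter) shows. Compound 3 `CN1CCN(CCCOc2cccc3nc(Nc4cccc(Cl)c4)ccc23)CC1` differs from compound 2 by hydrogen in place of chloro on an aromatic carbon. Going by the values given here, the only step on record, the aryl swap from compound 1 to compound 2, left the read-out within the scatter, so for compound 3 a step of about a 1.3-fold higher number from compound 2 to compound 3 (0.11 log units; within the scatter) is expected, not beyond the scatter. Compound 3 is estimated at 2500 nM, range 1000 nM to 6000 nM.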

Compound 3, concentration for 50% growth inhibition: 1910 nM
The estimate for compound 3 lay 1.3-fold (0.12 log units) above the measured number; low and high end bracket the measured number.
By their numbers in this assay, from the lowest: compounds 3, 2 and 1 (each within the scatter of the next).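

In this assay one of the two chloro groups on the aryl amine can be replaced by hydrogen with the step staying within the scatter: a 1.0-fold lower number from compound 2 to compound 3 (0.01 log units; within the scatter). The step of a 1.1-fold lower number from compound 1 to compound 3 (0.06 log units; within the scatter) is also within the scatter, so 3-chlorophenyl joins 3,5-dichlorophenyl and 4-isopropylphenyl as groups on this nitrogen whose numbers cannot be told apart. No supporting measurement bears on this result.

Still open, going by these compounds, is whether a phenyl ring without any chloro, or one carrying an amine or a carboxylic acid, would take the number beyond the scatter.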